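The compounds below may be only part of what the source reports. "The series", "measured", "known", "first", "only" and "open" are said of these compounds alone.

Compound 1 `CNc1ncnc2c1c(-c1ccoc1)cn2[C@@H]1O[C@H](CO)[C@@H](O)[C@H]1O`, compound 2 `CNc1ncnc2c1c(-c1ccsc1)cn2[C@@H]1O[C@H](CO)[C@@H](O)[C@H]1O` and compound 3 `CNc1ncnc2c1c(-c1cc3ccccc3o1)cn2[C@@H]1O[C@H](CO)[C@@H](O)[C@H]1O` share one core and differ in the group on an aromatic carbon. In a functional assay on CCRF-CEM cells (Homo sapiens), read by MTT assay, with a stated time of 72 h (a lower number here means a stronger inhibitor, a higher number a weaker inhibitor), compound 1 gives > 20000 nM, a limit. Compound 2 gives > 20000 nM, also a limit. Compound 3 gives > 20000 nM, again a limit. Compound 3 thus stands at the limit of > 20000 nM in this assay, at which 3 of the 3 values shown sit.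

Compound 4 `CNc1ncnc2c1c(I)cn2[C@@H]1O[C@H](CO)[C@@H](O)[C@H]1O` has not yet been measured. It differs from compound 3 by the change (iodo in place of 1-benzofuran-2-yl on an aromatic carbon). The measured steps give no size: a step that the two limits leave unreadable from compound 1 to compound 2, a step that the two limits leave unreadable from compound 1 to compound 3 and a step that the two limits leave unreadable from compound 2 to compound 3. Any expectation in this assay is therefore weak, and only a modest gain is expected, if any.

The estimated step is an at least 1.6-fold lower number from compound 3 to compound 4 (0.22 log units; that floor lies within the scatter). For compound 4 the expected value is 12000 nM, with an estimated range of 1500 nM to 20000 nM.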

Compound 4, half-maximal inhibitory concentration: > 100000 nM
Compound 4 was reported as a limit; the forecaster's own chance of this, stated with the estimate: 55%; middle value at least 8.3-fold (0.92 log units) away from the limit.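

In this assay, within the data shown here, compound 4 gives > 100000 nM, a limit; compound 1, compound 2 and compound 3 are also limits, so no step to compound 4 can be read. The compounds shown leave open how far iodo, furan-3-yl, thiophen-3-yl and 1-benzofuran-2-yl differ on the shared core.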